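Ethoxycarbonyl on compound 1: expected effect on cell inhibition

The compounds below may be only part of what the source reports. "The series", "measured", "known", "first", "only" and "open" are said of these compounds alone.

In a functional assay on HCT-116 cells (Homo sapiens) for inhibition, read by CCK-8 assay, with a stated time of 48 h (a lower number here means a stronger inhibitor, a higher number a weaker inhibitor), compound 1 `COc1cc(-c2ccnc3cc(-c4ccccc4)nn23)cc(OC)c1OC` gives 3880 nM and sits at the high end of the three measured numbers. It lies within the scatter of compound 3 `COc1cc(-c2ccnc3cc(-c4cccc(C)c4)nn23)cc(OC)c1OC` at 6150 nM and far from compound 2 `COc1cc(-c2ccnc3cc(-c4ccc5c(ccn5C)c4)nn23)cc(OC)c1OC` at 39 nM on the low side.

Compound 4 `CCOC(=O)c1ccc(-c2cc3nccc(-c4cc(OC)c(OC)c(OC)c4)n3n2)cc1` differs from compound 1 by a single change, (ethoxycarbonyl in place of hydrogen on an aromatic carbon), with ethoxycarbonyl in place of hydrogen on an aromatic carbon of a six-membered aromatic ring of carbon only, para to a large group.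

The nearest guide is the other addition in place of hydrogen, methyl on an aromatic carbon: a 1.6-fold higher number from compound 1 to compound 3 (0.20 log units; within the scatter) stays within the scatter. The large steps, a 99-fold lower number from compound 1 to compound 2 (2.00 log units; beyond the scatter) and a 160-fold higher number from compound 2 to compound 3 (2.20 log units; beyond the scatter), both turn on 1-methyl-1H-indol-5-yl, which compound 4 does not carry, so they bear on it only weakly. Among the measured compounds shown here, no measured compound carries ethoxycarbonyl, so the guide is thin and the range is kept wide.

No step beyond the scatter is expected in this assay. The expected step is a 1.3-fold higher number from compound 1 to compound 4 (0.11 log units; within the scatter) and would stay within the scatter. The estimate for compound 4 is 5000 nM, with an expected range from 1500 nM to 17000 nM for the measurement.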

Compound 4, half-maximal inhibitory concentration: > 10000 nM
Compound 4 gave a limit, no number; the forecaster's own chance of this, stated with the estimate: 10%; at least 2.0-fold (0.30 log units) between middle value and limit.
By their numbers in this assay, from the lowest: compound 2; then compounds 1 and 3 (each within the scatter of the next). At a limit, above all of these: compound 4.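

In this assay compound 4 gives > 10000 nM, which is a limit of the assay and not a number. Even so, ethoxycarbonyl in place of hydrogen, on an aromatic carbon of the six-membered ring para to a large group, gives an at least 2.5-fold higher number from compound 1 to compound 4 (0.41 log units; beyond the scatter), whereas methyl in place of hydrogen gives a 1.6-fold higher number from compound 1 to compound 3 (0.20 log units; within the scatter), so the ring of compound 1 does not accept every addition without a step beyond the scatter. How far past the limit compound 4 lies cannot be told from this series, and it is the only compound shown there: the limit of > 10000 nM in this assay, at which 1 of the 4 values shown sits.

The compounds shown leave open whether the step follows the whole ethoxycarbonyl group or only its ethyl part, a question that a carboxylic acid or a methyl ester at the same place would help to settle. Also open, as far as these compounds go, is how an amine, a methoxy group or a chlorine atom at that place would read in this assay, and whether any addition there moves the number lower rather than higher.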